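Sulfonyl Substituent Variation and Kinetic Solubility in One Series

The compounds below may be only part of what the source reports. "The series", "measured", "known", "first", "only" and "open" are said of these compounds alone.

Measured so far:
compound 1, `O=S(=O)(CCO)c1cccc(-c2ccc3nccc(-c4ccncc4)c3n2)c1`; in a physicochemical assay for solubility, read by HPLC, using the shake flask method, measured as kinetic solubility, with a stated time of 20 h, at pH 6.5, tested at 200 uM (on this read-out lower numbers stand for lower solubility and higher numbers for higher solubility), compound 1 gives 55000 nM
compound 2, `C[C@@H](CO)NS(=O)(=O)c1cccc(-c2ccc3nccc(-c4ccncc4)c3n2)c1`; in this assay compound 2 gives 50000 nM
compound 3, `CS(=O)(=O)Nc1cccc(-c2ccc3nccc(-c4ccncc4)c3n2)c1`; in this assay compound 3 gives 20000 nM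

Compound 3 stands lowest of the three numbers. Its two steps from the others are both beyond the scatter: a 2.8-fold lower number from compound 1 to compound 3 (0.44 log units; beyond the scatter) and a 2.5-fold lower number from compound 2 to compound 3 (0.40 log units; beyond the scatter). Between compound 1 and compound 2 there is no change to speak of: a 1.1-fold lower number from compound 1 to compound 2 (0.04 log units; within the scatter).

Compound 4, `O=S(=O)(c1cccc(-c2ccc3nccc(-c4ccncc4)c3n2)c1)N1CC[C@H](O)C1`, has not yet been measured in this assay. The change from compound 3 is (3-hydroxypyrrolidin-1-yl)sulfonyl in place of methanesulfonamido on an aromatic carbon. Among the compounds with values here, the steps that bear on it are the two that run from a sulfonyl carrying a hydroxylated substituent to methanesulfonamido, both modest and downward; compound 4 reverses that type of change, so a modest upward step, a 2.0-fold higher number from compound 3 to compound 4 (0.30 log units; within the scatter), is expected. Compound 4 is estimated at 40000 nM, with a range from 15000 nM to 90000 nM, resting on compound 2 at 50000 nM.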

Compound 4, solubility: 20000 nM
Beside the measured number, compound 4's estimate is 2.0-fold (0.30 log units) above it; the range from low to high includes it.
By their numbers in this assay, from the lowest: compounds 3 and 4 (each within the scatter of the next); then compounds 2 and 1 (each within the scatter of the next).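

In this assay, a hydroxyl on the group at the sulfonyl sulfur does not by itself place a compound with the two highest numbers, since the ring-closed 3-hydroxypyrrolidin-1-yl falls away from both open-chain substituents (a 2.5-fold lower number from compound 2 to compound 4 (0.40 log units; beyond the scatter); a 2.8-fold lower number from compound 1 to compound 4 (0.44 log units; beyond the scatter)). Exchanging methanesulfonamido for (3-hydroxypyrrolidin-1-yl)sulfonyl on the aromatic carbon reads as (no change at the digits printed from compound 3 to compound 4 (within the scatter)), even though the entering group brings more heavy atoms and a five-membered non-aromatic ring. No measurement shown here accounts for the gap between the ring-closed and open-chain substituents.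

Still open, on these data alone, is how an unsubstituted pyrrolidin-1-yl, the opposite stereocentre of the 3-hydroxypyrrolidin-1-yl or a morpholine on the sulfonyl sulfur would read. A longer chain on that sulfur ending in an amine or a carboxylic acid also remains to be placed in this series.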